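A few compounds are considered here, and "the series" means these few. Any claim that something is new, unique, unknown or untested is made for them only; others in the source may bear on it.

Measured so far in a functional assay on MCF7 cells (Homo sapiens); a higher number here means a weaker inhibitor, a lower number a stronger inhibitor
Compound 1 `COc1cc(NC(C)CCCNC(=O)NCCO)c2ncccc2c1` gives 25000 nM
Compound 2 `COc1cc(NC(C)CCCNC(=O)NC(CO)(CO)CO)c2ncccc2c1` gives 24000 nM
Compound 3 `COc1cc(NC(C)CCCNC(=O)NCCNC(=O)NCCCC(C)Nc2cc(OC)cc3cccnc23)c2ncccc2c1` gives 31000 nM

At 24000 nM compound 2 stands level with the other two compounds, as all three values lie within the scatter of one another. Compound 4 `CCOC(=O)NCCCC(C)Nc1cc(OC)cc2cccnc12` has not yet been measured. It carries ethoxy in place of (2-hydroxy-1,1-bis(hydroxymethyl)ethyl)amino on a carbonyl carbon. Among the compounds with values here, the only measured step that bears on this is a 1.0-fold lower number from compound 1 to compound 2 (0.02 log units; within the scatter) and it stays within the scatter. Within the data shown here, that step exchanged 2-hydroxyethyl for 2-hydroxy-1,1-bis(hydroxymethyl)ethyl on an amide-type nitrogen, so no measured compound shows what ethoxy does on the carbonyl carbon. The estimated change is a 1.2-fold lower number from compound 2 to compound 4 (0.08 log units; within the scatter) and thus none beyond the scatter is expected in this assay for now. Compound 4 is estimated at 20000 nM with 7000 nM to 50000 nM as the expected range.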

Compound 4, half-maximal inhibitory concentration: 26000 nM
Compound 4: middle estimate off by 1.3-fold (0.11 log units), on the low side; the measured number falls inside the stated range.
By their numbers in this assay, from the lowest: compounds 2, 1, 4 and 3 (each within the scatter of the next).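

In this assay, ethoxy on the carbonyl carbon in place of (2-hydroxy-1,1-bis(hydroxymethyl)ethyl)amino gives a 1.1-fold higher number from compound 2 to compound 4 (0.03 log units; within the scatter), and in place of (2-hydroxyethyl)amino it gives a 1.0-fold higher number from compound 1 to compound 4 (0.02 log units; within the scatter). The earlier single-place step changed only the group on the amide-type nitrogen, whereas these steps show that the whole amino group can be exchanged for ethoxy, with 0 hydrogen-bond donors, without a shift beyond the scatter. No evidence is available to explain this result. As far as these compounds go, what a carboxylic acid or a longer chain on this carbonyl carbon would do remains open, as does whether any group there moves the number beyond the scatter.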